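Swapping a Chain Acid for an Imidazole Tail

The source may report more compounds than this note shows. Statements on the series, on what has been measured and on what is new or still open speak of the compounds shown alone.

compound 1 `CCCCCCCCCCCC(=O)OC[C@H](CSC[C@@H](N)C(=O)NCCCCCCO)OC(=O)CCCCCCCCCCC`: 33 nM
compound 2 `CCCCCCCCCCCC(=O)OC[C@H](CSC[C@@H](N)C(=O)NC(CC)COC)OC(=O)CCCCCCCCCCC`: 71.8 nM
compound 3 `CCCCCCCCCCCC(=O)OC[C@H](CSC[C@@H](N)C(=O)NCCCCCCCCCC(=O)O)OC(=O)CCCCCCCCCCC`: 4400 nM

All three share one core and differ only in the group on the amide-type nitrogen. In an assay on HEK293 cells for agonist activity at Toll-like receptor 2 (Homo sapiens) (on this read-out lower numbers stand for an effect already at smaller amounts and higher numbers for an effect only at larger amounts of compound), compound 3 gives 4400 nM, the highest number of the three; the nearest is compound 2 at 71.8 nM, and compound 1 at 33 nM stands furthest away. Compound 4 `CCCCCCCCCCCC(=O)OC[C@H](CSC[C@@H](N)C(=O)NCCCn1ccnc1)OC(=O)CCCCCCCCCCC` keeps that core but carries 1H-imidazol-1-yl in place of 6-carboxyhexyl on a saturated chain carbon, three bonds along the chain from an amide-type nitrogen.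

Going by the values given here, two measured steps bear on this change. Going from the hydroxy-ended tail to the acid-ended tail gave a 130-fold higher number from compound 1 to compound 3 (2.12 log units; beyond the scatter), and going from the methoxymethylpropyl tail to the acid-ended tail gave a 61-fold higher number from compound 2 to compound 3 (1.79 log units; beyond the scatter), so the acid-ended chain belongs to the weakest compound. The two neutral tails lie close together, with a 2.2-fold higher number from compound 1 to compound 2 (0.34 log units; beyond the scatter).

Compound 4 has no acid; its tail is neutral. Since compound 1 gives 33 nM and compound 2 gives 71.8 nM with neutral tails, compound 4 is expected to return toward that level, a step of a 73-fold lower number from compound 3 to compound 4 (1.87 log units; beyond the scatter). Among the compounds with values here, no measured compound carries an imidazole ring, so the range stays wide. For compound 4 the estimate in this assay is 60 nM, between 15 nM and 300 nM.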

Compound 4, half-maximal effective concentration: 410 nM
The estimate for compound 4 lay 6.8-fold (0.83 log units) below the measured number, outside the stated range (above it).
By their numbers in this assay, from the lowest: compound 1; then compound 2; then compound 4; then compound 3.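

Taking away the acid-ended tail in favour of 3-(1H-imidazol-1-yl)propyl wins back only part of the ground in this assay with an 11-fold lower number from compound 3 to compound 4 (1.03 log units; beyond the scatter) and leaves this compound short of the two others that lack a carboxylic acid. Those gaps are a 5.7-fold higher number from compound 2 to compound 4 (0.76 log units; beyond the scatter) and the larger 12-fold higher number from compound 1 to compound 4 (1.09 log units; beyond the scatter) so the absence of the acid does not by itself bring a tail to the level of compound 1 or compound 2. At this position the tails without an acid therefore no longer sit close together, as compound 1 and compound 2 alone suggested, and what separates them has no measured explanation here.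

Compound 4 differs from compound 1 in both chain length and end group, so the compounds shown cannot say whether the shorter chain or the imidazole ring accounts for the higher number. A 6-(1H-imidazol-1-yl)hexyl tail would separate the two, and a 3-hydroxypropyl tail would test the same question from the other side, while an amine at the chain end remains an open alternative to the ring.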